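The compounds below may be only part of what the source reports. "The series", "measured", "known", "first", "only" and "open" are said of these compounds alone.

Measured compounds in an assay on HEK293F cells for inhibition of cholesterol 24-hydroxylase (Homo sapiens), read by trypan blue exclusion, with stated times of 15 min and 5 h; on this read-out higher numbers stand for weaker inhibition and lower numbers for stronger inhibition:
compound 1 `O=C(NC1CC1)C1CCN(c2cncnc2-c2ccccc2)CC1`: 44 nM
compound 2 `CNC(=O)C1CCN(c2cncnc2-c2ccccc2)CC1`: 72 nM
compound 3 `CCNC(=O)C1CCN(c2cncnc2-c2ccccc2)CC1`: 58 nM

Compound 3 stands second highest of the three numbers; its nearest neighbour is compound 2, its furthest compound 1, and both gaps sit within the scatter, so the three amides cannot be ranked against each other. The steps that replace one substituent on the amide-type nitrogen by another read a 1.6-fold higher number from compound 1 to compound 2 (0.21 log units; within the scatter), a 1.3-fold higher number from compound 1 to compound 3 (0.12 log units; within the scatter) and a 1.2-fold lower number from compound 2 to compound 3 (0.09 log units; within the scatter), none of them beyond the scatter.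

Compound 4 `O=C(Nc1ccccc1)C1CCN(c2cncnc2-c2ccccc2)CC1` has not yet been measured. It differs from compound 3 in one place: phenyl in place of ethyl on an amide-type nitrogen. The measured steps bear on it only in that they vary the same amide-type nitrogen, and all of them stayed within the scatter; none of them introduces an aromatic ring there, so the step to a phenyl group is less well covered than the earlier ones.

For compound 4 the expected step in this assay is therefore a 1.0-fold higher number from compound 3 to compound 4 (0.01 log units; within the scatter), that is, no change beyond the scatter, with a wider range than the measured steps because the phenyl group is a larger change. The estimated value for compound 4 is 60 nM, expected to lie between 15 nM and 240 nM.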

Compound 4, half-maximal inhibitory concentration: 28 nM
Estimate against measurement, compound 4: 2.1-fold (0.33 log units) above; the measured number falls inside the stated range.
By their numbers in this assay, from the lowest: compounds 4, 1, 3 and 2 (each within the scatter of the next, the first and the last beyond it).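

In this assay the amide-type nitrogen, where methyl, ethyl and cyclopropyl could not be told apart, gives its first differences beyond the scatter once phenyl stands on it, with a 2.1-fold lower number from compound 3 to compound 4 (0.32 log units; beyond the scatter) for phenyl in place of ethyl and a 2.6-fold lower number from compound 2 to compound 4 (0.41 log units; beyond the scatter) for phenyl in place of methyl. Against cyclopropyl the picture is different, since a 1.6-fold lower number from compound 1 to compound 4 (0.20 log units; within the scatter) for phenyl in place of cyclopropyl and so these two groups cannot be separated, which means the position accepts a six-membered aromatic ring of carbon only without any loss of inhibition but the gain is shown only against the two open-chain groups. No supporting measurement accompanies these numbers to account for the difference between phenyl and the open-chain groups.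

The compounds shown leave open how a benzyl group or a pyridine ring on the same nitrogen would read, and whether a fluorine or a methoxy group on the phenyl ring would move the number further. They also leave open what happens when a methyl group replaces the amide hydrogen, which all four compounds keep.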